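Amide in place of the acid on the shared core

The source may hold more compounds than are shown below. What is called first, only, known or untested is meant among the compounds shown, and "the series" means these compounds.

Compound 1 `CC(C)=CCC[C@]1(C)/C=C/[C@@H](OC(=O)C=C(C)C)[C@](C)(O)/C=C/C(=O)/C(C(=O)O)=C\C1` carries a carboxy group on its core. In a functional assay on A549 cells (Homo sapiens) for antiproliferative activity, read by MTT assay, with a stated time of 48 h (on this read-out lower numbers stand for stronger inhibition and higher numbers for weaker inhibition), compound 1 gives only a limit, > 10000 nM, and so it has no measured position on the numbers shown; it sits at the limit of > 10000 nM in this assay, at which 1 of the 2 values shown sits, rather than at a number. Compound 2 `CC(C)=CCC[C@](C)(/C=C/[C@@H](OC(=O)C=C(C)C)[C@](C)(O)/C=C/C(=O)/C=C/N(C)C)CC=O` is the open-chain relative in the set; in this assay compound 2 gives 11200 nM. Taken together, the two values of compounds 1 and 2 show nothing firmer than weak inhibition for both. Compound 3 `CCN(CC)C(=O)/C1=C/C[C@](C)(CCC=C(C)C)/C=C/[C@@H](OC(=O)C=C(C)C)[C@](C)(O)/C=C/C1=O` keeps the core of compound 1 and differs in one place: diethylamino in place of hydroxy on a carbonyl carbon. Within the data shown here, no measured step connects this pair, so its size is open. A modest gain beyond the scatter is expected, with a fair chance that the assay again returns only a limit; the expected step is an at least 2.0-fold lower number from compound 1 to compound 3 (0.30 log units; that floor lies within the scatter). Compound 3 is estimated at 5000 nM, between 1500 nM and 20000 nM.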

Compound 3, half-maximal inhibitory concentration: 11300 nM
Estimate against measurement, compound 3: 2.3-fold (0.35 log units) below; low and high end bracket the measured number.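

No step can be read from compound 1 to compound 3, because compound 1 stands only at a limit: the limit of > 10000 nM in this assay, at which 1 of the 3 values shown sits.

The compounds shown leave open how far diethylamino in place of hydroxy on a carbonyl carbon shifts the number on the shared core, or whether it shifts it at all.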